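Limits all round: a triazole aryl swap on the spiro core

A few compounds are considered here, and "the series" means these few. Any claim that something is new, unique, unknown or untested is made for them only; others in the source may bear on it.

Compound 1, `N#CC1=C(N)Oc2c(c3nc4ccccc4nc3c3ccccc23)C12C(=O)N(Cc1cnnn1-c1cccc(Br)c1)c1ccccc12`, in a functional assay on A549 cells (Homo sapiens) for antiproliferative activity, read by MTT assay, with a stated time of 48 h; a higher number here means a weaker inhibitor, a lower number a stronger inhibitor: > 50000 nM, a limit of the assay.
Compound 2, `Cc1ccc(-n2nncc2CN2C(=O)C3(C(C#N)=C(N)Oc4c3c3nc5ccccc5nc3c3ccccc43)c3ccccc32)cc1C`, in this assay: > 50000 nM, a limit of the assay.
Compound 3, `N#CC1=C(N)Oc2c(N)cc3nc4ccccc4nc3c2C12C(=O)N(Cc1cnnn1-c1ccc(F)cc1)c1ccccc12`, in this assay: > 50000 nM, a limit of the assay.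

Compound 3 stands where every measured compound stands: at the limit, with no number behind it. For the measured compounds named here, the only one-place step measured so far, a step that the two limits leave unreadable from compound 1 to compound 2, is unreadable because of the limit of > 50000 nM in this assay, at which 3 of the 3 values shown sit. Compound 4, `Cc1ccc(-n2nncc2CN2C(=O)C3(C(C#N)=C(N)Oc4c(N)cc5nc6ccccc6nc5c43)c3ccccc32)cc1Cl`, differs from compound 3 by 3-chloro-4-methylphenyl in place of 4-fluorophenyl on an aromatic nitrogen. Going by the values given here, that change sits on the same aromatic nitrogen as the swap from compound 1 to compound 2, so the one step that bears on it gives no size and no direction. With the three measured values all at the limit, nothing in the shown data suggests that compound 4 will move into the measurable range, and the expected step that the limit leaves unreadable from compound 3 to compound 4 is none beyond the scatter. Compound 4 is therefore estimated at 80000 nM, between 25000 nM and 300000 nM, most likely reported again as a limit.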

Compound 4, half-maximal inhibitory concentration: 11800 nM
For compound 4 the middle estimate is 6.8-fold (0.83 log units) above the measured one, outside the stated range (below it).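

In this assay, putting 3-chloro-4-methylphenyl in place of 4-fluorophenyl on the aromatic nitrogen gives an at least 4.2-fold lower number from compound 3 to compound 4 (0.62 log units; beyond the scatter) and brings the series its first real number. This position can therefore change the read-out: the aryl group here is not a silent part of the molecule, at least on the shared core of compound 3 and compound 4. As far as these compounds go, the full size of the step stays unknown because compound 3 sits at a limit and has no number of its own: the limit of > 50000 nM in this assay, at which 3 of the 4 values shown sit.

The compounds shown leave open whether the chlorine or the methyl carries the change, since neither 3-chlorophenyl nor 4-methylphenyl appears alone. They also leave open what a carboxylic acid or an amine on this aryl ring would do.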